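The source may hold more compounds than are shown below. What is called first, only, known or untested is meant among the compounds shown, and "the series" means these compounds.

Values in an ADME assay on HepG2 cells (Homo sapiens) for cytotoxicity, read by MTT assay, with a stated time of 72 h; a higher number here means that more compound is tolerated, a lower number that less compound is tolerated:
Compound 1 `O=[N+]([O-])c1cnc2c(Br)cc(Cl)cn12`: 16200 nM.
Compound 2 `CS(=O)(=O)Cc1nc2c(Br)cc(Cl)cn2c1N`: > 125000 nM, a limit of the assay.
Compound 3 `CS(=O)(=O)Cc1nc2c(Br)cc(Cl)cn2c1[N+](=O)[O-]`: 45000 nM.

Among the compounds with values here, compound 3 holds the higher of the two exact numbers, and the only other value above it is a limit. Compound 4 `C[S+]([O-])Cc1nc2c(Br)cc(Cl)cn2c1[N+](=O)[O-]` differs from compound 3 in one group: a group of 3 heavy atoms (1 carbon, 1 oxygen, 1 sulfur; no ring) in place of a group of 4 heavy atoms (1 carbon, 2 oxygen, 1 sulfur; no ring), on a saturated chain carbon bound to an aromatic carbon. The step that bears most is a 2.8-fold higher number from compound 1 to compound 3 (0.44 log units; beyond the scatter), which brought in the whole (methylsulfonyl)methyl group. The other step, an at least 2.7-fold lower number from compound 2 to compound 3 (0.44 log units; beyond the scatter), concerns nitro in place of amino and says little here. Only part of that group changes now, so no shift beyond the scatter is expected in this assay, and no direction is favoured. The estimated step is a 1.1-fold lower number from compound 3 to compound 4 (0.05 log units; within the scatter). For compound 4 the expected value is 40000 nM, with an estimated range of 15000 nM to 110000 nM.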

Compound 4, half-maximal cytotoxic concentration: 51400 nM
Estimate against measurement, compound 4: 1.3-fold (0.11 log units) below, within the range that was stated.
By their numbers in this assay, from the lowest: compound 1; then compounds 3 and 4 (each within the scatter of the next). At a limit, above all of these: compound 2.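

In this assay, replacing methylsulfonyl on the saturated chain carbon bound to an aromatic carbon leaves the number within the scatter: a 1.1-fold higher number from compound 3 to compound 4 (0.06 log units; within the scatter). At this position the read-out does not separate the two sulfur groups, and the rise over the core of compound 1 is also seen with the smaller group: a 3.2-fold higher number from compound 1 to compound 4 (0.50 log units; beyond the scatter). Nothing measured here gives a cause for these results.

Still open, going by these compounds, is whether an amine or a carboxylic acid on this chain carbon would keep the number in the same region. Also open, on these data alone, is whether amino in place of nitro would give a similar shift alongside the smaller sulfur group.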